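Limit readings ahead of the 3,4-dichlorophenyl change

The compounds below may be only part of what the source reports. "The series", "measured", "known", "first", "only" and "open" are said of these compounds alone.

In a functional assay on Raji cells (Homo sapiens) for cytotoxicity, with a stated time of 72 h (on this read-out lower numbers stand for an effect already at smaller amounts and higher numbers for an effect only at larger amounts of compound), compound 1 (`C=C[C@@](C)(/C=C/c1ccc(Nc2ccccc2)cc1)CCC=C(C)C`) gives > 26000 nM as a limit. Compound 2 (`C=C[C@@](C)(/C=C/c1ccc(-c2cccc(F)c2)cc1)CCC=C(C)C`) gives > 26000 nM as a limit too. For the measured compounds named here, the only measured step that the two limits leave unreadable from compound 1 to compound 2 has no readable size, with the limit of > 26000 nM in this assay, at which 2 of the 2 values shown sit, as its whole evidence. Compound 3 (`C=C[C@@](C)(/C=C/c1ccc(-c2ccc(Cl)c(Cl)c2)cc1)CCC=C(C)C`) carries 3,4-dichlorophenyl in place of 3-fluorophenyl, para to a large group (3,4-dichlorophenyl in place of 3-fluorophenyl on an aromatic carbon). No size can be carried over, so no step beyond the scatter is expected in this assay in either direction. The expected change is a number no higher from compound 2 to compound 3 (the limit leaves the size open) and no more. Compound 3 is estimated at 26000 nM with an expected range from 10000 nM to 50000 nM and a likely limit reading.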

Compound 3, half-maximal effective concentration: > 26000 nM
Compound 3: only a limit was reported; the forecaster's own chance of this, stated with the estimate: 70%; the middle value lies on the limit itself.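

No step can be read between compound 1, compound 2 and compound 3 in this assay, since each reading is a limit: the limit of > 26000 nM in this assay, at which 3 of the 3 values shown sit.

As far as these compounds go, whether any change at this place on the shared core moves the read-out, and how far, stays open.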